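A few compounds are considered here, and "the series" means these few. Any claim that something is new, unique, unknown or untested is made for them only; others in the source may bear on it.

Values measured so far in a physicochemical assay for lipophilicity, at pH 7.4 (on this read-out higher numbers stand for higher lipophilicity and lower numbers for lower lipophilicity), are:

compound 1 `CNC(=O)c1cc(C(N)=O)cc2c1OC[C@H]2c1ccccc1` gives 2.7
compound 2 `CNC(=O)c1cc(C(=O)Nc2cnn(C)c2)cc2c1OC[C@H]2c1ccccc1` gives 3.5
compound 3 `CNC(=O)c1cc(C(=O)NC2CC2)cc2c1OC[C@H]2c1ccccc1` gives 3.6

Compound 3 (3.6) stands level with compound 2, the gap being a number 0.10 log units higher from compound 2 to compound 3 (within the scatter) and no real difference. Against the parent amide the picture is clearer, with a number 0.90 log units higher from compound 1 to compound 3 (beyond the scatter) as one modest step and a number 0.80 log units higher from compound 1 to compound 2 (beyond the scatter) as a similar one.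

Compound 4 `CNC(=O)c1cc(C(=O)N[C@H]2C[C@@H]2C)cc2c1OC[C@H]2c1ccccc1` departs from compound 3 at a single place, where cyclopropyl becomes 2-methylcyclopropyl: methyl in place of hydrogen on a saturated ring carbon with methyl in place of hydrogen on a saturated ring carbon. Among the compounds with values here, no measured step adds a methyl group to this ring, so the data offer only an indirect guide. The closest is a number 0.90 log units higher from compound 1 to compound 3 (beyond the scatter) for a whole cyclopropyl group in place of hydrogen on an amide-type nitrogen. The methyl group is a smaller addition, so a smaller rise in the same direction is expected, and it may only just clear the scatter. The expected step is a number 0.30 log units higher from compound 3 to compound 4 (within the scatter) in this assay on this estimate. For compound 4 the estimated value is 3.9 with 3.6 to 4.3 as the expected range.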

Compound 4, distribution coefficient: 4.5
For compound 4 the middle estimate is 0.60 log units below the measured one; measured number above the stated range.
By their numbers in this assay, from the lowest: compound 1; then compounds 2 and 3 (each within the scatter of the next); then compound 4.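

In this assay compound 2 and compound 3 had stood level, so the groups on this amide nitrogen seemed to offer little separation, but methyl in place of hydrogen on a saturated ring carbon of the cyclopropyl group gives a number 0.90 log units higher from compound 3 to compound 4 (beyond the scatter). That single carbon matches in size the earlier step for the entire cyclopropyl group, which was a number 0.90 log units higher from compound 1 to compound 3 (beyond the scatter), so a small change on this three-membered ring counted as much as adding the ring itself. It also separates the 2-methylcyclopropyl amide from the pyrazole amide, with a number 1.00 log units higher from compound 2 to compound 4 (beyond the scatter), and widens the span from the parent amide to a number 1.80 log units higher from compound 1 to compound 4 (beyond the scatter), while nothing available accounts for why the methyl group counts for so much here.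

As far as these compounds go, whether a longer chain such as ethyl on the same ring carbon would raise the read-out further, or a hydroxyl group or an amine there would bring it back down, stays open. So does whether the same methyl group would give a step of this size on a cyclobutyl ring or on the other arrangements of the 2-methylcyclopropyl group.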